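This account rests on a few compounds, and the source may have more. Where it says the series, first, only, none or still open, it means among the compounds named here.

Measured so far in a functional assay on A549 cells (Homo sapiens) for cytotoxicity, read by MTT assay; on this read-out lower numbers stand for stronger inhibition and higher numbers for weaker inhibition: compound 1 `CCOC(=O)Nc1ccc(S(=O)(=O)N2C[C@H](c3ccccc3)NC2=O)cc1CC` gives 60 nM; compound 2 `CCc1cc(S(=O)(=O)N2C[C@H](c3ccccc3)NC2=O)ccc1NC(=O)c1ccc([N+](=O)[O-])cc1` gives 700 nM.

Compound 2 carries the highest number of the two; its nearest neighbour is compound 1, separated from it by a 12-fold higher number from compound 1 to compound 2 (1.07 log units; beyond the scatter). Compound 3 `CCc1cc(S(=O)(=O)N2C[C@H](c3ccccc3)NC2=O)ccc1NC(=O)OCC(C)C` differs from compound 2 by isobutoxy in place of 4-nitrophenyl on a carbonyl carbon. For the measured compounds named here, the single measured step that bears on this change is the one between compound 1 and compound 2, and the change to compound 3 runs it in reverse, with isobutoxy instead of ethoxy. A drop of about that size in this assay is therefore expected, namely a 7.8-fold lower number from compound 2 to compound 3 (0.89 log units; beyond the scatter). Compound 3 is estimated at 90 nM, within a range from 30 nM to 300 nM.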

Compound 3, half-maximal inhibitory concentration: 70 nM
Estimate against measurement, compound 3: 1.3-fold (0.11 log units) above; low and high end bracket the measured number.
By their numbers in this assay, from the lowest: compounds 1 and 3 (each within the scatter of the next); then compound 2.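

In this assay, for the compounds shown here, the change to isobutoxy on this carbonyl carbon gives a 10-fold lower number from compound 2 to compound 3 (1.00 log units; beyond the scatter) and so shows that ethoxy is not the only group there that stands well apart from 4-nitrophenyl. Ethoxy and isobutoxy do not separate, with a 1.2-fold higher number from compound 1 to compound 3 (0.07 log units; within the scatter) for isopropyl in place of methyl on the saturated chain carbon bound to an oxygen next to a carbonyl group. No evidence is available to explain these results.

On these data alone, whether a plain phenyl, an amine or a longer chain on this carbonyl carbon would match compound 1 or compound 2 remains open. So does whether the nitro group or the ring of 4-nitrophenyl accounts for the gap.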